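From compound 2 to compound 3: a larger hydroxylated chain

A few compounds are considered here, and "the series" means these few. Any claim that something is new, unique, unknown or untested is made for them only; others in the source may bear on it.

Measured so far in an ADME assay on S9 fraction from liver (Homo sapiens) for metabolic stability, read by LC-MS, using NADPH, with stated times of 5 min and 60 min, tested at 5 uM; a higher number here means that more of the compound is left, a lower number that less of the compound is left
Compound 1 `COc1cc(C2CN(C(=O)c3cc(OCCCC(=O)O)ccn3)C2)ccc1OCc1ccc(C2CC2)cc1` gives 91%
Compound 2 `COc1cc(C2CN(C(=O)c3cc(COC[C@H](O)CO)ccn3)C2)ccc1OCc1ccc(C2CC2)cc1` gives 62%

Of these two numbers, compound 2 holds the lower, and the gap to compound 1 lies beyond the scatter. Among the measured compounds shown here, the only measured step is a number 29 percentage points lower from compound 1 to compound 2 (beyond the scatter) and it puts (2,3-dihydroxypropoxy)methyl in place of 3-carboxypropoxy on an aromatic carbon.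

Compound 3 `COc1cc(C2CN(C(=O)c3cc(COCC(CO)(CO)CO)ccn3)C2)ccc1OCc1ccc(C2CC2)cc1` remains unmeasured and keeps the shared core of compound 2. The change is 2-hydroxy-1,1-bis(hydroxymethyl)ethyl in place of 1,2-dihydroxyethyl on a saturated chain carbon bound to an oxygen on a saturated carbon and it turns (2,3-dihydroxypropoxy)methyl into (3-hydroxy-2,2-bis(hydroxymethyl)propoxy)methyl.

For the measured compounds named here, the one measured step bears on this change only loosely, as it replaces a different group. Going by the values given here, no measured pair alters the 1,2-dihydroxyethyl end of the chain. Compound 3 is therefore expected to stay near compound 2 in this assay and no step beyond the scatter is expected, though neither direction can be excluded. The estimated change is a number 3 percentage points higher from compound 2 to compound 3 (within the scatter) on this thin evidence. The expected value for compound 3 is 65% with an estimated range of 42% to 85% in this read-out.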

Compound 3, percent of the compound remaining: 85%
Compound 3: middle estimate off by 20 percentage points, on the low side; the measured number falls inside the stated range.
By their numbers in this assay, from the lowest: compound 2; then compounds 3 and 1 (each within the scatter of the next).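

In this assay, the end of this chain turns out to matter: exchanging the 1,2-dihydroxyethyl end for 2-hydroxy-1,1-bis(hydroxymethyl)ethyl gives a number 23 percentage points higher from compound 2 to compound 3 (beyond the scatter). Among the compounds shown here, the earlier compounds could not show this, since their one step exchanged the whole substituent, whereas this one leaves the inner part of the chain in place. Comparing the whole substituents, (3-hydroxy-2,2-bis(hydroxymethyl)propoxy)methyl in place of 3-carboxypropoxy on an aromatic carbon gives a number 6 percentage points lower from compound 1 to compound 3 (within the scatter), and nothing on hand gives a cause for the effect of the chain end.

The change from compound 2 to compound 3 alters the number of hydroxyl groups and the branching together and also removes the one defined stereocentre, so the compounds shown do not separate these features. As far as these compounds go, how this assay would respond to a simple 2-hydroxyethyl end, to a branched end capped with methoxy groups, or to an amine on the same chain carbon remains open.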